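Phenyl in Place of Methyl on Two Related Cores

The source may report more compounds than this note shows. Statements on the series, on what has been measured and on what is new or still open speak of the compounds shown alone.

Measured so far in a physicochemical assay for lipophilicity; on this read-out higher numbers stand for higher lipophilicity and lower numbers for lower lipophilicity:
compound 1, `CCN(CCn1cc[n+](C)c1/C=N/O)S(=O)(=O)C(F)(F)F`, gives -1.03
compound 2, `C[n+]1ccn(CCN(Cc2ccccc2)S(=O)(=O)C(F)(F)F)c1/C=N/O`, gives -0.01
compound 3, `CCN(CCCn1cc[n+](C)c1/C=N/O)S(=O)(=O)C(F)(F)F`, gives -1.02

Compound 1 and compound 2 differ by phenyl in place of methyl on a saturated chain carbon bound to a sulfonamide nitrogen, and in this assay the step was a number 1.02 log units higher from compound 1 to compound 2 (beyond the scatter). Compound 4, `C[n+]1ccn(CCCN(Cc2ccccc2)S(=O)(=O)C(F)(F)F)c1/C=N/O`, stands to compound 3 as compound 2 stands to compound 1: the change is phenyl in place of methyl on a saturated chain carbon bound to a sulfonamide nitrogen, the same change at the same place. The difference between the two cores is not broken down here; the values of compound 1 and compound 3 lie within the scatter of each other. For compound 4 a step of the same size is expected, a number 1.02 log units higher from compound 3 to compound 4 (beyond the scatter). This expectation rests on the measured step of a number 1.02 log units higher from compound 1 to compound 2 (beyond the scatter) and on the value of compound 3, -1.02. Compound 4 is accordingly estimated at 0, with a range from -0.4 to 0.4.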

Compound 4, distribution coefficient: 0.06
The estimate for compound 4 lay 0.06 log units below the measured number; measured number inside the range.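

In this assay the change of methyl to phenyl gave a number 1.08 log units higher from compound 3 to compound 4 (beyond the scatter) on one core and a number 1.02 log units higher from compound 1 to compound 2 (beyond the scatter) on the other, so across these two cores the step kept its direction and stayed large. This rests on one pair for each core and shows nothing about how the change would behave on any further core. Nothing shown here explains the size of either step.

The compounds shown leave open whether an amine or a carboxylic acid in place of phenyl, at the same place, would give a comparable step. They also leave open whether the step would hold on a core with a longer chain.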